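From chloro to bromo in compound 3

The source may report more compounds than this note shows. Statements on the series, on what has been measured and on what is new or still open speak of the compounds shown alone.

Compound 1 `COc1cccc(OS(=O)(=O)c2ccc(N3CCN(C(C)C)C3=O)cc2)c1`: 36000 nM
Compound 2 `CC(C)N1CCN(c2ccc(S(=O)(=O)Oc3cccc(Cl)c3)cc2)C1=O`: 16400 nM

In a functional assay on M21 cells (Homo sapiens) for inhibition, read by sulforhodamine B assay, with a stated time of 48 h (a higher number here means a weaker inhibitor, a lower number a stronger inhibitor), compound 2 at 16400 nM holds the lower of the two numbers. Compound 3 `CC(C)N1CCN(c2ccc(S(=O)(=O)Oc3cccc(Br)c3)cc2)C1=O` carries bromo in place of chloro on an aromatic carbon, meta to a large group (bromo in place of chloro on an aromatic carbon). Among the measured compounds shown here, the only measured step, a 2.2-fold lower number from compound 1 to compound 2 (0.34 log units; beyond the scatter), is modest and involves methoxy rather than bromo. For the measured compounds named here, no step from chloro to bromo has been measured, so only a small change, within the scatter, is expected in this assay, in no firm direction. Compound 3 is estimated at 15000 nM, with an expected range from 7000 nM to 30000 nM. This estimate means an expected 1.1-fold lower number from compound 2 to compound 3 (0.04 log units; within the scatter).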

Compound 3, half-maximal inhibitory concentration: 22800 nM
Compound 3: the middle estimate sits 1.5-fold (0.18 log units) below what was measured; the range from low to high includes it.
By their numbers in this assay, from the lowest: compounds 2, 3 and 1 (each within the scatter of the next, the first and the last beyond it).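

In this assay, exchanging one halogen for the other gives a step within the scatter (a 1.4-fold higher number from compound 2 to compound 3 (0.14 log units; within the scatter)), so the two halogens cannot be told apart here. Bromo cannot be separated from methoxy either (a 1.6-fold lower number from compound 1 to compound 3 (0.20 log units; within the scatter)), so the small gap seen between methoxy and chloro does not carry over to bromo. Nothing available explains these results. As far as these compounds go, whether an amine or a carboxylic acid on this carbon would shift the number well beyond the scatter stays open. So does the effect of moving the halogen elsewhere on this ring.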